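The compounds below may be only part of what the source reports. "The series", "measured", "known", "first", "only" and "open" are said of these compounds alone.

Measured in a functional assay on the whole organism (Tail, strain ICR) with Mus musculus as the target, in the tail flick test, with a stated time of 120 min, at a dose of 25 umol/kg by the oral route; on this read-out higher numbers stand for a stronger effect at the one dose given and lower numbers for a weaker effect:
- compound 1 `O=C(CN(c1nc(Cl)nc2[nH]cnc12)C1CC1)N[C@@H](CO)C(=O)OCc1ccccc1` gives 34.5%
- compound 2 `NC(=O)CC[C@H](NC(=O)CN(c1nc(Cl)nc2[nH]cnc12)C1CC1)C(=O)OCc1ccccc1` gives 36%

Going by the values given here, compound 2 and compound 1 lie within the scatter of each other in this assay, the one recorded step being a number 1.5 percentage points higher from compound 1 to compound 2 (within the scatter). Compound 3 `CC(C)C[C@H](NC(=O)CN(c1nc(Cl)nc2[nH]cnc12)C1CC1)C(=O)OCc1ccccc1` is not yet measured in this assay. It differs from compound 2 by isopropyl in place of carbamoylmethyl on a saturated chain carbon, two bonds along the chain from an amide-type nitrogen and a carbonyl carbon.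

The step from compound 1 to compound 2 concerns the same place on the chain, but exchanges hydroxy for carbamoylmethyl, not carbamoylmethyl for isopropyl, so it bears on the new change only in showing that one variation there stayed within the scatter. Among the compounds with values here, no measured step involves isopropyl at this place. With that single, indirect precedent, the expected step of no change at the digits printed from compound 2 to compound 3 (within the scatter) is none beyond the scatter, though the range must stay wide. Compound 3 is estimated at 36%, between 16% and 56%.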

Compound 3, a percentage reported as activity, at one dose (the size of the read-out at that dose, not a potency): 8.58%
Compound 3: the middle estimate sits 27.4 percentage points above what was measured; measured number below the stated range.
By their numbers in this assay, from the lowest: compound 3; then compounds 1 and 2 (each within the scatter of the next).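

In this assay, the saturated chain carbon two bonds along the chain from an amide-type nitrogen and a carbonyl carbon now proves sensitive to its substituent, which the earlier pair did not show. Isopropyl in place of carbamoylmethyl gives a number 27.4 percentage points lower from compound 2 to compound 3 (beyond the scatter), and isopropyl in place of hydroxy gives a number 25.9 percentage points lower from compound 1 to compound 3 (beyond the scatter), so among these three compounds, hydroxy and carbamoylmethyl stand together against isopropyl. Nothing available explains this loss of effect.

The compounds shown leave open how a carboxylic acid or an amine would read at this place, and whether a longer carbon chain would stay as low as compound 3. With a single dose and a single time, they also leave open whether these steps would hold under other conditions.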